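A few compounds are considered here, and "the series" means these few. Any claim that something is new, unique, unknown or untested is made for them only; others in the source may bear on it.

Series notes. Compound 1 `CCOC(=O)N1CCC(=NNC(=O)c2ccc(F)cc2)CC1`, compound 2 `O=C(NN=C1CC(c2ccccc2)NC(c2ccccc2)C1)c1ccccc1` and compound 3 `O=C(NN=C1CC(c2ccccc2)NC(c2ccccc2)C1)c1ccc(F)cc1` have been run in a functional assay on A549 cells (Homo sapiens) for cytotoxicity, read by MTT assay, with a stated time of 24 h; on this read-out higher numbers stand for weaker inhibition and lower numbers for stronger inhibition. Compound 1 gives only a limit, > 400000 nM. Compound 2 likewise gives only a limit, > 400000 nM. Compound 3 also gives only a limit, > 400000 nM. The step that the two limits leave unreadable from compound 2 to compound 3 is thus not readable, as shown by the limit of > 400000 nM in this assay, at which 3 of the 3 values shown sit. Compound 4 `Cc1ccc(C(=O)NN=C2CC(c3ccccc3)NC(c3ccccc3)C2)cc1` is not yet measured; it differs from compound 3 by methyl in place of fluoro on an aromatic carbon. Within the data shown here, no measured step with a readable size bears on this change, and the step from compound 2 to compound 3 gives no size at all. The step that the limit leaves unreadable from compound 3 to compound 4 is therefore expected to be none beyond the scatter, with a further limit the most likely outcome. In this assay compound 4 is estimated at 600000 nM, within a range from 150000 nM to 3000000 nM.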

Compound 4, half-maximal inhibitory concentration: > 400000 nM
Compound 4: only a limit was reported (the forecaster's own chance of this, stated with the estimate: 85%); the middle value does not contradict the limit.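

The steps to compound 4 from compound 2 and from compound 3 cannot be read, as each value is only a limit: the limit of > 400000 nM in this assay, at which 4 of the 4 values shown sit.

The compounds shown leave open how hydrogen, fluoro and methyl compare at this position.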